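This account rests on a few compounds, and the source may have more. Where it says the series, first, only, none or still open, it means among the compounds named here.

Among the measured compounds shown here, compound 2 `COc1cc(C(=O)O)ccc1C=C1CCN(C(=O)C(C2CCCCC2)C2CCCCC2)CC1` gives 130 nM in an assay on isolated protein for inhibition of 3-oxo-5-alpha-steroid 4-dehydrogenase 2 (Homo sapiens) (on this read-out higher numbers stand for weaker inhibition and lower numbers for stronger inhibition), and of the two numbers measured so far it stands as the higher one; compound 1 `O=C(O)c1ccc(C=C2CCN(C(=O)C(C3CCCCC3)C3CCCCC3)CC2)c(F)c1` gives 11 nM in this assay. For the measured compounds named here, the one measured step between these two compounds, a 12-fold higher number from compound 1 to compound 2 (1.07 log units; beyond the scatter), is the only guide available here. Compound 3 `O=C(O)Cc1ccc(C=C2CCN(C(=O)C(C3CCCCC3)C3CCCCC3)CC2)c(F)c1` has not yet been measured, and it differs from compound 2 by 4-(carboxymethyl)-2-fluorophenyl in place of 4-carboxy-2-methoxyphenyl on a double-bonded chain carbon bound to a double-bonded ring carbon. Going by the values given here, this change brings back the fluoro found in compound 1, but it also lengthens the acid by one chain carbon, and no measured pair shows what such lengthening does on its own. The return of the fluoro is expected to reverse much of the rise seen in going from compound 1 to compound 2, so a step of a 4.3-fold lower number from compound 2 to compound 3 (0.64 log units; beyond the scatter) is expected in this assay. Compound 3 is therefore estimated at 30 nM, with a range from 8 nM to 120 nM.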

Compound 3, half-maximal inhibitory concentration: 7 nM
The estimate for compound 3 lay 4.3-fold (0.63 log units) above the measured number, and the stated range ends above it.
By their numbers in this assay, from the lowest: compounds 3 and 1 (each within the scatter of the next); then compound 2.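

Carboxymethyl in place of carboxy on an aromatic carbon gives a 1.6-fold lower number from compound 1 to compound 3 (0.20 log units; within the scatter) in this assay, so with the fluoro kept, this extra chain carbon on the acid has no effect that can be told apart from the scatter. The larger step, a 19-fold lower number from compound 2 to compound 3 (1.27 log units; beyond the scatter), combines that lengthening with fluoro in place of methoxy, and the pair above suggests that the lengthening contributes little to it, leaving the difference between fluoro and methoxy as the likelier source. Nothing available explains how either group acts on this read-out.

Going by these compounds, it remains open whether the carboxymethyl acid would give a similar number with a methoxy on the ring instead of the fluoro. Also open, on these data alone, is whether a longer acid chain, such as carboxyethyl, or a chloro in place of the fluoro would keep the number this low.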